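The source may report more compounds than this note shows. Statements on the series, on what has been measured and on what is new or still open speak of the compounds shown alone.

Measured compounds in a functional assay on cells for agonist activity at Glucose-dependent insulinotropic receptor (Homo sapiens), read by a luciferase reporter, with a stated time of 6 h; a higher number here means that more compound is needed for the effect, a lower number that less compound is needed:
- compound 2, `CCc1cnc(N2CCC(c3nc(COc4ccc(/C=C5\CC(=O)NC5=O)cc4F)cs3)CC2)nc1`, gives 49 nM
- compound 3, `CCc1cnc(N2CCC(c3nc(COc4ccc(/C=C5\CC(=O)NC5=O)cc4C)cs3)CC2)nc1`, gives 18 nM
- compound 1, `O=C(O)CCc1cnc(N2CCC(c3nc(COc4ccc(-n5cnnn5)cc4)cs3)CC2)nc1`, gives "not determined" (no result reported)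

Compound 2 stands highest of the two numbers in this assay. Its nearest neighbour is compound 3, and the change from fluoro to methyl on the aromatic carbon gives a 2.7-fold lower number from compound 2 to compound 3 (0.43 log units; beyond the scatter), a modest step that lies beyond the usual scatter.

Compound 4, `CC(C)(C)OC(=O)N1CCC(c2nc(COc3ccc(/C=C4\CC(=O)NC4=O)cc3F)cs2)CC1`, differs from compound 2 at a different place: tert-butoxycarbonyl in place of 5-ethylpyrimidin-2-yl on an amine nitrogen in a ring. Among the measured compounds shown here, the only measured step concerns a substituent on the aromatic ring, far from the amine nitrogen in the ring, so no measured step bears directly on this exchange. The expectation for compound 4 therefore rests on the value of compound 2 alone, and the exchange of a whole aromatic ring for a group with no ring is a larger change than any step measured here, so a wider range is appropriate.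

Compound 4 is expected to need somewhat more compound than compound 2, an estimated step of a 3.1-fold higher number from compound 2 to compound 4 (0.49 log units; beyond the scatter). The estimate for compound 4 in this assay is 150 nM, with a range from 40 nM to 600 nM.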

Compound 4, half-maximal effective concentration: 157 nM
For compound 4 the middle estimate is 1.0-fold (0.02 log units) below the measured one; the range from low to high includes it.
By their numbers in this assay, from the lowest: compound 3; then compound 2; then compound 4.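

Among the compounds shown here, this is the first measured change at the amine nitrogen of the six-membered non-aromatic ring; the earlier step concerned only a substituent on an aromatic carbon. Putting tert-butoxycarbonyl in place of 5-ethylpyrimidin-2-yl gives a 3.2-fold higher number from compound 2 to compound 4 (0.51 log units; beyond the scatter) in this assay and so costs only a modest amount of activity, even though an aromatic ring with two hetero atoms gives way to a group with no ring. At this position, then, the aromatic ring is not needed for compound 4 to give a measurable effect in the nanomolar range, although 5-ethylpyrimidin-2-yl gives the lower number of the two. No measurement shown here explains the size of this step.

The compounds shown leave open whether the nitrogen needs a substituent at all, which a free amine would test, and whether a small acetyl group or a simple phenyl ring would behave more like tert-butoxycarbonyl or like 5-ethylpyrimidin-2-yl. They also leave open whether methyl in place of fluoro on the aromatic carbon would lower the number in the same way with tert-butoxycarbonyl on the nitrogen.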